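The source may hold more compounds than are shown below. What is called first, only, known or untested is meant among the compounds shown, and "the series" means these compounds.

Measured so far:
compound 1 `CCCCCCCCCCCCn1nnc(C(C(=O)Nc2c(OC)cc(OC)cc2OC)c2ccc(OC)cc2)n1` — 200 nM
compound 2 `CCCCCCCCCCCCn1nnc(C(F)C(=O)Nc2c(OC)cc(OC)cc2OC)n1` — 1760 nM

Among the measured compounds shown here, in an assay on liver for inhibition of sterol O-acyltransferase 1 (Rattus norvegicus), using microsomes (a lower number here means a stronger inhibitor, a higher number a weaker inhibitor), compound 2 gives 1760 nM and stands at the higher of the two numbers, with compound 1 as its only neighbour at 200 nM. Compound 3 `CCCCCCCCCCCCn1nnc(C(C(=O)Nc2c(OC)cc(OC)cc2OC)c2ccccn2)n1` differs from compound 2 by the change (pyridin-2-yl in place of fluoro on a saturated chain carbon bound to an aromatic carbon and a carbonyl carbon). For the measured compounds named here, the one measured step that bears on this position is an 8.8-fold higher number from compound 1 to compound 2 (0.94 log units; beyond the scatter), in which an aromatic ring at that carbon gave way to fluoro and the number rose well beyond the scatter. Compound 3 restores an aromatic ring at the same carbon, though a six-membered ring with one nitrogen rather than 4-methoxyphenyl, so a step back down is expected, estimated as a 4.4-fold lower number from compound 2 to compound 3 (0.64 log units; beyond the scatter), most likely not the full reversal seen between compound 1 and compound 2. On that basis compound 3 is expected to give about 400 nM in this assay, within a range of 120 nM to 1300 nM.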

Compound 3, half-maximal inhibitory concentration: 590 nM
For compound 3 the middle estimate is 1.5-fold (0.17 log units) below the measured one; the range from low to high includes it.
By their numbers in this assay, from the lowest: compound 1; then compound 3; then compound 2.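

In this assay the saturated chain carbon bound to an aromatic carbon and a carbonyl carbon has now carried three groups, and pyridin-2-yl falls apart from both others: there is a 3.0-fold lower number from compound 2 to compound 3 (0.47 log units; beyond the scatter) when it replaces fluoro and a 3.0-fold higher number from compound 1 to compound 3 (0.47 log units; beyond the scatter) when it replaces 4-methoxyphenyl. Both aromatic rings thus give lower numbers than fluoro, yet they are not interchangeable, and compound 1 keeps the lowest number of the three. Nothing available here explains this order.

Compound 1 and compound 3 differ in both the ring nitrogen and the methoxy group, so the shown compounds cannot tell which of the two accounts for the gap; a plain phenyl or a 4-methoxypyridin-2-yl group at this carbon would separate them. Going by these compounds, how a pyridin-3-yl or pyridin-4-yl group would compare also remains open.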